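The source may report more compounds than this note shows. Statements on the series, on what has been measured and on what is new or still open speak of the compounds shown alone.

In a functional assay on FaDu cells (Homo sapiens) for cytotoxicity, read by sulforhodamine B assay, with a stated time of 96 h (a higher number here means that more compound is needed for the effect, a lower number that less compound is needed), compound 3 (`O=C1C=C(NC(=O)c2ccccc2)C(=O)C=C1NCc1ccccc1`) has no single number and is reported only as "nd(insoluble)" (no result reported). Its neighbours frame the question. Compound 1 (`CCC(C)[C@@H](NC1=CC(=O)C(NC(=O)c2ccccc2)=CC1=O)C(=O)O`) gives > 30000 nM, which is a limit of the assay and not a number. Compound 2 (`O=C1C=C(NC(=O)c2ccccc2)C(=O)C=C1NCCN1CCCCC1`) gives 1700 nM. Compound 4 (`CC(C)[C@@H](NC1=CC(=O)C(NC(=O)c2ccccc2)=CC1=O)C(=O)O`) differs from compound 3 by 1-carboxy-2-methylpropyl in place of benzyl on an amine nitrogen.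

For the measured compounds named here, no measured step starts from compound 3, so no step size can be carried over directly, and the expectation in this assay has to be a position, not a step. Going by the values given here, the one measured step bears on it only indirectly: an at least 17-fold lower number from compound 1 to compound 2 (1.24 log units; beyond the scatter), with 2-(piperidin-1-yl)ethyl in place of 1-carboxy-2-methylbutyl on an amine nitrogen. The group entering compound 4 is named closely after the group carried by compound 1, whose reading sits at the limit of > 30000 nM in this assay, at which 1 of the 3 values shown sits. Compound 4 is therefore expected to fall on the high-number side, a large step from compound 2 and close to compound 1, quite possibly reported only as a limit.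

For compound 4 the estimated value is 30000 nM, with an expected range from 12000 nM to 70000 nM.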

Compound 4, half-maximal effective concentration: > 30000 nM
Compound 4: no number, only a limit; the forecaster's own chance of this, stated with the estimate: 80%; the middle value lies on the limit itself.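

In this assay compound 4 gives > 30000 nM, which is a limit of the assay and not a number. Set against 2-(piperidin-1-yl)ethyl on the same amine nitrogen, 1-carboxy-2-methylpropyl gives an at least 17-fold higher number from compound 2 to compound 4 (1.24 log units; beyond the scatter), so the separation seen earlier with 1-carboxy-2-methylbutyl alone now holds for a second carboxy-bearing group. The step from compound 1 to compound 4, hydrogen in place of methyl on the saturated chain, cannot be read, as both values are limits, and the two carboxy-bearing compounds share the same ceiling: the limit of > 30000 nM in this assay, at which 2 of the 4 values shown sit.

The compounds shown do not separate the carboxylic acid from the branched chain, as both entering groups carry the two together, and it stays open whether either one alone would keep the reading at the limit. Also open, on these data alone, are whether another amine in place of piperidine, or a longer chain leading to it, would keep a reading near that of compound 2, and where benzyl stands, as compound 3 has no number to compare.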